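Carboxy for hydroxymethyl on a saturated chain carbon

The source may hold more compounds than are shown below. What is called first, only, known or untested is meant among the compounds shown, and "the series" means these compounds.

Measured compounds in this series:
Compound 1, `Cn1nc(Cc2nnc(SCC(=O)Nc3ccc(Cl)cc3Cl)n2CCCO)c2ccccc2c1=O`, in an assay on 32D cells for inhibition of interleukin-15 (Mus musculus), read by resazurin assay, with stated times of 30 min and 2.5 days, in the presence of a further agent that is not named here (on this read-out higher numbers stand for weaker inhibition and lower numbers for stronger inhibition), gives > 30000 nM, a limit of the assay rather than a number.
Compound 2, `Cn1nc(Cc2nnc(SCC(=O)Nc3ccc(Cl)cc3Cl)n2CCC(=O)O)c2ccccc2c1=O`, in this assay gives > 30000 nM, again a limit and not a number.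
Compound 3, `Cn1nc(Cc2nnc(SCCCCCCCC(=O)Nc3ccc(Cl)cc3Cl)n2CCCO)c2ccccc2c1=O`, in this assay gives > 30000 nM, also a limit and not a number.

The change from compound 1 to compound 2 is carboxy in place of hydroxymethyl on a saturated chain carbon, two bonds along the chain from an aromatic nitrogen. The step it made in this assay is a step that the two limits leave unreadable from compound 1 to compound 2. Both ends of that step are limits, so the size of the step cannot be read; what can be said rests on (the limit of > 30000 nM in this assay, at which 3 of the 3 values shown sit).

Compound 3 carries the same core as compound 1 on one side and a longer thioether chain on the other, and the difference between the two cores is not broken down here. Compound 4, `Cn1nc(Cc2nnc(SCCCCCCCC(=O)Nc3ccc(Cl)cc3Cl)n2CCC(=O)O)c2ccccc2c1=O`, has not yet been measured. It stands to compound 3 as compound 2 stands to compound 1: the change is carboxy in place of hydroxymethyl on a saturated chain carbon, two bonds along the chain from an aromatic nitrogen, the same change at the same place.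

Since the change that led from compound 1 to compound 2 left both values at the limit, and since compound 3 itself sits at > 30000 nM, the expectation is that compound 4 will also report only a limit. The step expected in this assay from compound 3 to compound 4 is a step that the limit leaves unreadable from compound 3 to compound 4, with the estimate for compound 4 at 60000 nM and a range from 20000 nM to 200000 nM.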

Compound 4, half-maximal inhibitory concentration: 23500 nM
Estimate against measurement, compound 4: 2.6-fold (0.41 log units) above; low and high end bracket the measured number.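

In this assay, carboxy in place of hydroxymethyl on the core with the longer thioether chain gives an at least 1.2-fold lower number from compound 3 to compound 4 (0.10 log units; that floor lies within the scatter), and compound 4, at 23500 nM, is the only compound shown that reports a number. Compound 3 gives > 30000 nM, a limit of the assay and not a number, so the step to compound 4 has only a floor, and that floor alone does not set compound 4 apart from compound 3. The same change on the core of compound 1 cannot be read, since both ends of that step are limits, so the series does not show whether the change carries the same size of step from one core to the other: the limit of > 30000 nM in this assay, at which 3 of the 4 values shown sit.

Still open, as far as these compounds go, is whether the number for compound 4 depends on the carboxy group, on the longer thioether chain, or on the two together, and whether a thioether chain of intermediate length would also bring a carboxy compound into the measurable range. From the compounds shown here alone, it is equally open whether an amine or a primary amide in place of the carboxy group, on a saturated chain carbon, two bonds along the chain from an aromatic nitrogen, would give a number rather than a limit.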